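Compound 3 to compound 4: a change of phenyl group

The source may report more compounds than this note shows. Statements on the series, on what has been measured and on what is new or still open speak of the compounds shown alone.

Measured so far in a functional assay on MDA-MB-231 cells (Homo sapiens) for antiproliferative activity, read by MTT assay, with a stated time of 72 h (on this read-out higher numbers stand for weaker inhibition and lower numbers for stronger inhibition), as follows
compound 1 `C#Cc1cccc(NC(=O)CCc2cccc3c2B(O)OC3)c1` gives 1600 nM
compound 2 `Cc1cc(C)c(NC(=O)CCc2cccc3c2B(O)OC3)c(C)c1` gives 71000 nM
compound 3 `O=C(CCc1cccc2c1B(O)OC2)Nc1cccc(-c2cccc(F)c2)c1` gives 570 nM

Compound 3 has the lowest of the three numbers in this assay and sits well under compound 2. Compound 4 `COc1ccc(-c2cccc(NC(=O)CCc3cccc4c3B(O)OC4)c2)cc1` carries 4-methoxyphenyl in place of 3-fluorophenyl on an aromatic carbon, meta to a large group, with the count 4-methoxyphenyl in place of 3-fluorophenyl on an aromatic carbon as the difference. Among the compounds with values here, the one measured step bearing on this place is a 2.8-fold lower number from compound 1 to compound 3 (0.45 log units; beyond the scatter) and it replaced ethynyl, so no measured pair compares two phenyl groups. That modest step sets a small scale, and no shift beyond the scatter is expected in this assay in either direction. The expected change is a 1.1-fold higher number from compound 3 to compound 4 (0.02 log units; within the scatter) in this read-out. For compound 4 the estimate is 600 nM with an expected range of 200 nM to 1800 nM as the outer ends.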

Compound 4, half-maximal inhibitory concentration: 88 nM
Compound 4: middle estimate off by 6.8-fold (0.83 log units), on the high side, outside the stated range (below it).
By their numbers in this assay, from the lowest: compound 4; then compound 3; then compound 1; then compound 2.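

In this assay, within the data shown here, the phenyl groups at this position are not interchangeable: the one comparison of two phenyl groups gives (a 6.5-fold lower number from compound 3 to compound 4 (0.81 log units; beyond the scatter)), a step beyond the scatter. The step against ethynyl is larger (an 18-fold lower number from compound 1 to compound 4 (1.26 log units; beyond the scatter)), so the choice of group on this aromatic carbon carries more weight than the earlier step suggested. Nothing available explains the difference between these groups.

The step changes both the substituent and its place on the phenyl ring, and the compounds shown do not separate the two. Going by these compounds, how 4-fluorophenyl or 3-methoxyphenyl would read remains open.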